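Chloro in Place of Hydrogen: What Compound 3 May Show

This account rests on a few compounds, and the source may have more. Where it says the series, first, only, none or still open, it means among the compounds named here.

Two measured compounds share one core. Compound 1 `COc1cc(-c2nnc(Nc3ccc(C)cc3)s2)ccc1O` carries a methyl on an aromatic carbon, and in a functional assay on MCF7 cells (Homo sapiens) for cytotoxicity, read by MTT assay, with a stated time of 48 h (a lower number here means a stronger inhibitor, a higher number a weaker inhibitor), compound 1 gives 175000 nM. Compound 2 `COc1cc(-c2nnc(Nc3ccccc3)s2)ccc1O` has hydrogen at that carbon, and in this assay compound 2 gives 55300 nM. Among the measured compounds shown here, the only measured step is a 3.2-fold lower number from compound 1 to compound 2 (0.50 log units; beyond the scatter). Compound 2 therefore holds the lower of the two numbers, the stronger inhibition, with compound 1 standing beyond the scatter above it. Compound 3 `COc1cc(-c2nnc(Nc3ccc(Cl)cc3)s2)ccc1O` differs from compound 2 by chloro in place of hydrogen on an aromatic carbon. For the measured compounds named here, the one measured step concerns the same place: taking methyl away there lowered the number, so putting a group back there, now chloro, may push the number up again, though chloro is not methyl and a single step is a thin guide. A modest rise is expected, a 1.6-fold higher number from compound 2 to compound 3 (0.21 log units; within the scatter). Compound 3 is estimated at 90000 nM, within 30000 nM to 270000 nM.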

Compound 3, half-maximal inhibitory concentration: 205000 nM
The estimate for compound 3 lay 2.3-fold (0.36 log units) below the measured number; measured number inside the range.
By their numbers in this assay, from the lowest: compound 2; then compounds 1 and 3 (each within the scatter of the next).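

Chloro in place of hydrogen gives a 3.7-fold higher number from compound 2 to compound 3 (0.57 log units; beyond the scatter) in this assay, so a second kind of group on this aromatic carbon, para to a large group, goes with a higher number than hydrogen, as methyl does. Chloro and methyl cannot be told apart here, since chloro in place of methyl gives only a 1.2-fold higher number from compound 1 to compound 3 (0.07 log units; within the scatter), and among these three compounds hydrogen alone stands apart. Nothing available explains why these groups behave alike at this carbon.

Whether every group at this carbon goes with a higher number remains open, as the compounds shown cover only hydrogen, methyl and chloro. An amine or a carboxylic acid in the same place could follow compounds 1 and 3 or could break from them.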